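Chlorine to fluorine on a shared core, judged from limits

The source may hold more compounds than are shown below. What is called first, only, known or untested is meant among the compounds shown, and "the series" means these compounds.

Compound 1 `COc1ccc(/C=C/c2cc(OC)cc(OC)c2/C=C/C(=O)c2cc3ccc(Cl)cc3oc2=O)cc1` was examined in an assay on isolated protein for inhibition of Amine oxidase [flavin-containing] A (Homo sapiens), read by fluorescence, with a stated time of 15 min; on this read-out lower numbers stand for stronger inhibition and higher numbers for weaker inhibition. In this assay compound 1 gives only a limit of > 60000 nM, so no number stands for it. Compound 2 `COc1ccc(/C=C/c2cc(OC)cc(OC)c2/C=C/C(=O)c2cc3cc(Cl)ccc3oc2=O)cc1` differs from compound 1 by a step that the two limits leave unreadable from compound 1 to compound 2. In this assay compound 2 also gives only a limit of > 60000 nM. The size of the step between the two cannot be read, because of the limit of > 60000 nM in this assay, at which 2 of the 2 values shown sit.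

Compound 3 `COc1ccc(/C=C/c2cc(OC)cc(OC)c2/C=C/C(=O)c2cc3cc(F)ccc3oc2=O)cc1` has not yet been measured. It differs from compound 1 in one place: a group of 12 heavy atoms (9 carbon, 2 oxygen, 1 fluorine; one six-membered aromatic ring of carbon only, one six-membered aromatic ring with 1 hetero atom) in place of a group of 12 heavy atoms (9 carbon, 2 oxygen, 1 chlorine; one six-membered aromatic ring of carbon only, one six-membered aromatic ring with 1 hetero atom), on a carbonyl carbon. Going by the values given here, the single measured step, from compound 1 to compound 2, bears on this change only loosely, since it exchanges the whole group on the carbonyl carbon and its size is not readable; the two limits give no hint of any movement. For compound 3 in this assay a value of 90000 nM is expected, with a range from 30000 nM to 300000 nM, and it is expected to appear most likely as a limit again. That expectation means a step that the limit leaves unreadable from compound 1 to compound 3, expected to lie within the scatter.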

Compound 3, half-maximal inhibitory concentration: 44300 nM
For compound 3 the middle estimate is 2.0-fold (0.31 log units) above the measured one; low and high end bracket the measured number.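

Among the three compounds shown, compound 3 alone gives a number rather than a limit in this assay, so fluoro in place of chloro on an aromatic carbon yields the first readable value on the shared core. The change reads as an at least 1.3-fold lower number from compound 2 to compound 3 (0.13 log units; that floor lies within the scatter), and the exchange of the whole group on the carbonyl carbon reads as an at least 1.3-fold lower number from compound 1 to compound 3 (0.13 log units; that floor lies within the scatter). Both steps are floors and not full sizes, and neither floor clears the scatter, because the other two compounds stay at a limit: the limit of > 60000 nM in this assay, at which 2 of the 3 values shown sit.

The true size of these steps remains open, as does the step between compound 1 and compound 2, which cannot be read, and no step shown separates the two halogens from any other group on that aromatic carbon. How a bromine, an amine or a carboxylic acid at the same place would read in this assay is left open, as is whether a plain hydrogen there would give a number at all.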